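The source may hold more compounds than are shown below. What is called first, only, known or untested is meant among the compounds shown, and "the series" means these compounds.

Measured compounds: compound 1 `Cc1cnn(C(=O)NCc2ccc(OCc3ccccc3)cc2)c1` with 1000 nM; compound 2 `O=C(N1CCCCC1)n1cccn1` with 6600 nM; compound 3 `Cc1cnn(C(=O)NCc2ccc(OC(c3ccccc3)c3ccccc3)cc2)c1` with > 100000 nM.

In an assay on membranes from brain for binding affinity to Monoglyceride lipase (Mus musculus), read by fluorescence, with stated times of 1 h and 30 min (a lower number here means a stronger inhibitor, a higher number a weaker inhibitor), compound 1 gives 1000 nM. Compound 2, a smaller urea, gives 6600 nM in this assay. For compound 3 the assay reports only a limit, > 100000 nM, so its true position is not known beyond that; it is one of the entries described by the limit of > 100000 nM in this assay, at which 1 of the 3 values shown sits. Among the compounds with values here, the one step measured within this set, an at least 100-fold higher number from compound 1 to compound 3 (2.00 log units; beyond the scatter), concerns the diphenylmethyl ether and says nothing about the substituent on the five-membered ring.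

Compound 4 `N#Cc1cnn(C(=O)NCc2ccc(OC(c3ccccc3)c3ccccc3)cc2)c1` differs from compound 3 by cyano in place of methyl on an aromatic carbon. Within the data shown here, no measured step bears on that change, so no direction can be drawn from the data in hand, and the starting point is itself only a limit. Compound 4 is therefore expected to give about 30000 nM in this assay, in a range from 1000 nM to 100000 nM, which would mean an estimated step of an at least 3.3-fold lower number from compound 3 to compound 4 (0.52 log units; beyond the scatter).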

Compound 4, half-maximal inhibitory concentration: > 100000 nM
Compound 4: no number, only a limit; the forecaster's own chance of this, stated with the estimate: 40%; at least 3.3-fold (0.52 log units) between middle value and limit.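

In this assay compound 4 gives only a limit, > 100000 nM, and compound 3 also gives only a limit, so no step between them can be read: the limit of > 100000 nM in this assay, at which 2 of the 4 values shown sit.

The compounds shown leave open what cyano in place of methyl does to the number.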